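Triazole aryl swap on the sesquiterpene-derived series

A few compounds are considered here, and "the series" means these few. Any claim that something is new, unique, unknown or untested is made for them only; others in the source may bear on it.

Working notes. The series shares a terpenoid core; compound 1 `CC(C)=CCC/C(C)=C/CC/C(C)=C/CC[C@@H]1[C@@]2(C)CC/C(=N\OCc3cn(-c4c(Cl)cc([N+](=O)[O-])cc4Cl)nn3)C(C)(C)[C@@H]2CC[C@@]1(C)O` and compound 2 `CC(C)=CCC/C(C)=C/CC/C(C)=C/CC[C@@H]1[C@@]2(C)C/C(=C\c3ccc(OCc4cn(-c5ccccc5)nn4)cc3)C(=O)C(C)(C)[C@@H]2CC[C@@]1(C)O` have been run in a functional assay on MCF7 cells (Homo sapiens) for cytotoxicity, read by MTT assay, with a stated time of 48 h; a lower number here means a stronger inhibitor, a higher number a weaker inhibitor. Compound 1 gives 16600 nM, and compound 2 gives 23000 nM; the two numbers lie within the usual scatter of each other, so neither stands apart. Compound 3 `CC(C)=CCC/C(C)=C/CC/C(C)=C/CC[C@@H]1[C@@]2(C)C/C(=C\c3ccc(OCc4cn(-c5c(Cl)cc([N+](=O)[O-])cc5Cl)nn4)cc3)C(=O)C(C)(C)[C@@H]2CC[C@@]1(C)O` is not yet measured. The change from compound 2 to compound 3 is 2,6-dichloro-4-nitrophenyl in place of phenyl on an aromatic nitrogen. Among the measured compounds shown here, no measured step of this kind exists in the set; a step within the scatter is expected, because compound 1 already carries the same group at 16600 nM. For compound 3 the expected value is 15000 nM, with a range from 5000 nM to 45000 nM, meaning an expected step of a 1.5-fold lower number from compound 2 to compound 3 (0.19 log units; within the scatter).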

Compound 3, half-maximal inhibitory concentration: 27100 nM
Estimate against measurement, compound 3: 1.8-fold (0.26 log units) below; measured number inside the range.
By their numbers in this assay, from the lowest: compounds 1, 2 and 3 (each within the scatter of the next).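

In this assay, 2,6-dichloro-4-nitrophenyl in place of phenyl on the aromatic nitrogen gives a 1.2-fold higher number from compound 2 to compound 3 (0.07 log units; within the scatter) and so leaves the number unmoved within the scatter. Among the compounds shown here, compounds 1 and 2 differ in more than one place, so this is the first reading of the aryl group alone, and at this position on this core the larger substituted ring is no better or worse than plain phenyl. No supporting data explain this result.

On these data alone, whether an amine or a carboxylic acid on this aryl ring would give a step beyond the scatter remains open. So does whether the same swap reads alike on the core of compound 1.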